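The compounds below may be only part of what the source reports. "The series", "measured", "known", "first", "only" and "open" are said of these compounds alone.

Measured so far in a functional assay on IMR-32 cells (Homo sapiens) for antiproliferative activity, read by sulforhodamine B assay, with a stated time of 48 h (on this read-out lower numbers stand for stronger inhibition of growth and higher numbers for weaker inhibition of growth), are these values:
compound 1 `O=C1COc2ccccc2N1CCCn1cc(-c2ccccc2)nn1` gives 370 nM here
compound 2 `COc1ccc(-c2cn(CCCN3C(=O)COc4ccccc43)nn2)cc1` gives 49900 nM here
compound 3 `CCCCCCc1cn(CCCN2C(=O)COc3ccccc32)nn1` gives 710 nM here

Compound 3 lies within the scatter of compound 1 and far below compound 2. Compound 4 `O=C1COc2ccccc2N1CCCn1cc(-c2cccnc2)nn1` has pyridin-3-yl in place of hexyl on an aromatic carbon. The nearest measured exchange, a 1.9-fold higher number from compound 1 to compound 3 (0.28 log units; within the scatter) on going from phenyl to hexyl, stays small. Yet a 130-fold higher number from compound 1 to compound 2 (2.13 log units; beyond the scatter) and a 70-fold lower number from compound 2 to compound 3 (1.85 log units; beyond the scatter) show that a change on the aromatic ring can be large. Going by the values given here, no measured step covers a ring nitrogen. A small step is expected in this assay, estimated as a 1.7-fold higher number from compound 3 to compound 4 (0.23 log units; within the scatter) overall, with the greater risk towards higher numbers. For compound 4 the estimate is 1200 nM with an expected range from 250 nM to 15000 nM in this read-out.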

Compound 4, concentration for 50% growth inhibition: 860 nM
Compound 4: middle estimate off by 1.4-fold (0.14 log units), on the high side; low and high end bracket the measured number.
By their numbers in this assay, from the lowest: compounds 1, 3 and 4 (each within the scatter of the next, the first and the last beyond it); then compound 2.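

In this assay, a ring nitrogen in the aryl group at this aromatic carbon costs little: the change is modest, with a 2.3-fold higher number from compound 1 to compound 4 (0.37 log units; beyond the scatter), and compared with the hexyl compound it stays within the scatter, with a 1.2-fold higher number from compound 3 to compound 4 (0.08 log units; within the scatter). The steep loss seen with 4-methoxyphenyl does not carry over to pyridin-3-yl, which shows a 58-fold lower number from compound 2 to compound 4 (1.76 log units; beyond the scatter), so an aromatic ring at this carbon does not in itself give a number as high as that of compound 2. No measurement here offers an explanation for these steps.

As far as these compounds go, it remains open how an amine or a carboxylic acid on the aryl ring would read out here. From the compounds shown here alone, a chain longer than hexyl at this carbon is equally open.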